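The compounds below may be only part of what the source reports. "The series", "measured", "known", "first", "only" and "open" are said of these compounds alone.

Compound 1 `Cc1cn(C2CCN(Cc3cccc(Oc4cc(F)cc(F)c4)c3)CC2)c(=O)[nH]c1=O` opens the series. In an ADME assay on MRC5 cells (Homo sapiens) for cytotoxicity, read by fluorescence and resazurin assay, with a stated time of 3 days (on this read-out higher numbers stand for weaker inhibition and lower numbers for stronger inhibition), compound 1 gives > 64000 nM, which is a limit of the assay rather than a number, as the limit of > 64000 nM in this assay, at which 1 of the 2 values shown sits, shows. Compound 2 `Cc1cn(C2CCN(Cc3cccc(Oc4ccncc4)c3)CC2)c(=O)[nH]c1=O` shares the same core. In this assay compound 2 gives "not determined" (no result reported), so no single number stands for it. Compound 3 `Cc1cn(C2CCN(Cc3cccc(Oc4cccc(Cl)c4)c3)CC2)c(=O)[nH]c1=O` differs from compound 2 by 3-chlorophenyl in place of pyridin-4-yl on an oxygen on an aromatic ring. For the measured compounds named here, no measured step covers this change, so in this assay no shift beyond the usual scatter is expected in either direction. Compound 3 is therefore estimated at about 50000 nM, expected between 15000 nM and 100000 nM.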

Compound 3, half-maximal inhibitory concentration: 21000 nM
The estimate for compound 3 lay 2.4-fold (0.38 log units) above the measured number; the measured number falls inside the stated range.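

For the compounds shown here, replacing 3,5-difluorophenyl with 3-chlorophenyl on the oxygen gives an at least 3.0-fold lower number from compound 1 to compound 3 (0.48 log units; beyond the scatter) in this assay, so this position can change the read-out, and compound 3 gives the first exact number for it. The full size of the step remains unknown because compound 1 stands at a limit of the assay: the limit of > 64000 nM in this assay, at which 1 of the 3 values shown sits.

Compound 2 has no reported result, so the steps involving pyridin-4-yl cannot be read. As far as these compounds go, how an unsubstituted phenyl, or a phenyl carrying an amine or a carboxylic acid, would read on this oxygen remains open.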